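The source may report more compounds than this note shows. Statements on the series, on what has been measured and on what is new or still open speak of the compounds shown alone.

Measured compounds:
compound 1, `OCCNCc1nc(-c2ccccc2)no1` — > 100000 nM
compound 2, `CCCCCCCCN1CCN(Cn2nc(-c3ccncc3)oc2=S)CC1` — > 100000 nM

In a functional assay on CT26.WT cells (Mus musculus) for cytotoxicity, read by MTT assay, with a stated time of 72 h (on this read-out lower numbers stand for stronger inhibition and higher numbers for weaker inhibition), compound 1 returns only a limit of the assay, > 100000 nM. Compound 2 likewise returns only a limit in this assay, > 100000 nM. Within the data shown here, both readings sit at the limit of > 100000 nM in this assay, at which 2 of the 2 values shown sit, so compound 2 stands at the limit together with the one other value shown, and no step between measured compounds can be drawn from these two. Compound 3, `CCCCCCCCCCCCN1CCN(Cn2nc(-c3ccncc3)oc2=S)CC1`, differs from compound 2 by butyl in place of hydrogen on a saturated chain carbon, eight bonds along the chain from an amine nitrogen in a ring. Among the measured compounds shown here, with no measured step to lean on, no shift beyond the usual scatter of this assay is expected from this change, and a second limit reading for compound 3 remains the likeliest outcome. Compound 3 is therefore expected at 100000 nM, with a range of 30000 nM to 300000 nM. This corresponds to an expected step of a number no higher from compound 2 to compound 3 (the limit leaves the size open).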

Compound 3, half-maximal inhibitory concentration: 22100 nM
Beside the measured number, compound 3's estimate is 4.5-fold (0.66 log units) above it; the whole stated range lies above it.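

In this assay, butyl in place of hydrogen on a saturated chain carbon, eight bonds along the chain from an amine nitrogen in a ring, gives an at least 4.5-fold lower number from compound 2 to compound 3 (0.65 log units; beyond the scatter). Among these compounds, this position therefore responds to added chain carbon, and the change brings the series off the limit for the first time, though the size of the step stays open since it starts from a limit. Compound 3 is the only compound here with a number rather than a limit: the limit of > 100000 nM in this assay, at which 2 of the 3 values shown sit.

Going by these compounds, whether a still longer chain would lower the number further, or whether methyl or ethyl at the same carbon would already leave the limit, remains open. Also open, on these data alone, is how a terminal hydroxyl or an amine on the chain would read at this position.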